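Two thiophene analogs and a dichloro variant awaiting measurement

The compounds below may be only part of what the source reports. "The series", "measured", "known", "first", "only" and "open" are said of these compounds alone.

Measured so far:
Compound 1, `O=C(/C=C/c1ccc(N2CCCCC2)cc1)c1ccc(I)s1`: 22000 nM
Compound 2, `c1cc(C2=NNC(c3ccc(N4CCCCC4)cc3)C2)cs1`: 27000 nM

Of the compounds shown here, two have been tested in an ADME assay on CCRF-CEM cells (Homo sapiens) for cytotoxicity, with a stated time of 5 days; on this read-out lower numbers stand for stronger inhibition and higher numbers for weaker inhibition. Compound 1 carries an iodothiophene joined through a carbonyl and a double bond to a piperidine-substituted phenyl, and in this assay compound 1 gives 22000 nM. Compound 2 replaces that chain with a five-membered non-aromatic ring holding two nitrogens, and in this assay compound 2 gives 27000 nM. The two numbers lie within the scatter of each other, so compound 2 stands side by side with compound 1 rather than apart from it; neither can be called the more potent.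

Compound 3, `Clc1cc(C2=NNC(c3ccc(N4CCCCC4)cc3)C2)c(Cl)s1`, keeps the core of compound 2 and differs in one place: 2,5-dichlorothiophen-3-yl in place of thiophen-3-yl on a carbon with a double bond to nitrogen. Among the compounds with values here, no measured pair shows what such a change does here, so the expectation rests on compound 2 alone. A step from compound 2 to compound 3 of modest size is expected, most likely toward a lower number but not clearly beyond the scatter: a 1.8-fold lower number from compound 2 to compound 3 (0.26 log units; within the scatter). Compound 3 is therefore estimated at 15000 nM, with a range from 5000 nM to 45000 nM.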

Compound 3, half-maximal inhibitory concentration: 37700 nM
Compound 3: middle estimate off by 2.5-fold (0.40 log units), on the low side; the measured number falls inside the stated range.
By their numbers in this assay, from the lowest: compounds 1, 2 and 3 (each within the scatter of the next).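

Replacing thiophen-3-yl with 2,5-dichlorothiophen-3-yl on a carbon with a double bond to nitrogen gives a 1.4-fold higher number from compound 2 to compound 3 (0.14 log units; within the scatter) in this assay. Within the data shown here, this is the first pair in the set that differs in one place, and it shows that the chlorine-bearing group can stand at this position without separating compound 3 from compound 2 beyond the usual scatter of the measurement. No measurement here offers any explanation for this result.

Among these compounds, a single pair tests only one change at one position, so it remains open whether a thiophene carrying only one chlorine, or a different group on the ring such as an amine or a carboxylic acid, would move the number beyond the scatter. As far as these compounds go, it also remains open whether the same exchange would behave in the same way on another core, such as the chain-linked core of compound 1, or whether changing the piperidine ring on the far side of the shared core would have a larger effect.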